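The source may hold more compounds than are shown below. What is called first, only, known or untested is meant among the compounds shown, and "the series" means these compounds.

Measured compounds:
compound 1, `O=C(CSc1nnnn1-c1cccc2ccccc12)N/N=C/c1ccco1`; in an ADME assay on MT4 cells (Homo sapiens) for cytotoxicity, read by MTT assay (on this read-out lower numbers stand for higher toxicity in this test and higher numbers for lower toxicity in this test), compound 1 reaches only a limit of the assay, > 330000 nM.
compound 2, `Cc1cccc(/C=N/NC(=O)CSc2nnnn2-c2cccc3ccccc23)c1`; in this assay compound 2 gives 269000 nM.
compound 3, `COc1ccc(/C=N/NC(=O)CSc2nnnn2-c2cccc3ccccc23)c(OC)c1`; in this assay compound 3 gives 28300 nM.

Among the two actual numbers, compound 3 stands lowest, with compound 2 nearest at a 9.5-fold lower number from compound 2 to compound 3 (0.98 log units; beyond the scatter). The third value, that of compound 1, is not a number but sits at the limit of > 330000 nM in this assay, at which 1 of the 3 values shown sits; from there the move to compound 3 is an at least 11-fold lower number from compound 1 to compound 3 (1.06 log units; beyond the scatter), whereas an at least 1.2-fold lower number from compound 1 to compound 2 (0.08 log units; that floor lies within the scatter) stays within the scatter. Both measured steps that end in compound 3 thus concern the arrival of the 2,4-dimethoxyphenyl group on the carbon double-bonded to nitrogen.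

Compound 4, `COc1cccc(/C=N/NC(=O)CSc2nnnn2-c2cccc3ccccc23)c1OC`, keeps the same atoms and only rearranges them: 2,3-dimethoxyphenyl in place of 2,4-dimethoxyphenyl on a carbon with a double bond to nitrogen. For the measured compounds named here, no measured step shifts one methoxy group around the ring, so the two steps into compound 3 bear on it only loosely, and a step in this assay of no more than modest size is expected, if at all beyond the scatter, with a slight lean toward a higher number. On that basis the expected step is a 1.4-fold higher number from compound 3 to compound 4 (0.15 log units; within the scatter). Compound 4 is estimated at 40000 nM, within a range from 15000 nM to 120000 nM.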

Compound 4, half-maximal cytotoxic concentration: 192000 nM
Estimate against measurement, compound 4: 4.8-fold (0.68 log units) below; measured number outside the range, above it.
By their numbers in this assay, from the lowest: compound 3; then compounds 4 and 2 (each within the scatter of the next). At a limit, above all of these: compound 1.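

Moving a single methoxy group, with the atoms and the counts of the group unchanged, gives a 6.8-fold higher number from compound 3 to compound 4 (0.83 log units; beyond the scatter) in this assay, so on a carbon with a double bond to nitrogen the read-out depends on how the two methoxy groups are arranged on the ring, not only on their presence. Two methoxy groups as such do not bring the low number of compound 3, since 2,3-dimethoxyphenyl in place of 3-methylphenyl gives only a 1.4-fold lower number from compound 2 to compound 4 (0.15 log units; within the scatter) and the marked drop so far belongs to 2,4-dimethoxyphenyl alone. Against furan-2-yl the comparison gives only a floor, an at least 1.7-fold lower number from compound 1 to compound 4 (0.23 log units; that floor lies within the scatter), and it cannot settle any difference, as the entry for compound 1 is a limit and not a number: the limit of > 330000 nM in this assay, at which 1 of the 4 values shown sits.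

The compounds shown leave open whether the 4-methoxy group alone, on a 4-methoxyphenyl ring, is enough for the low number, or whether it needs the 2-methoxy group with it. They also leave open what a hydroxyl, an amine or a chlorine at the same ring position would do in place of methoxy.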